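The source may report more compounds than this note shows. Statements on the series, on what has been measured and on what is new or still open speak of the compounds shown alone.

Working notes on the dithiocarbamate series.

Compound 1 `Cc1ccc(-n2cc(CSC(=S)N3CCN(C(=O)OC(C)(C)C)CC3)nn2)cc1`, compound 2 `O=C(OCc1ccccc1)N1CCN(C(=S)SCc2cn(Cc3ccc(Cl)c(Cl)c3)nn2)CC1` and compound 3 `Cc1ccc(Cn2cc(CSC(=S)N3CCN(C(=O)OCc4ccccc4)CC3)nn2)cc1` share a core and differ in the carbamate substituent and in the group on the saturated chain carbon bound to the aromatic nitrogen. In a functional assay on PC-3 cells (Homo sapiens) for inhibition, read by MTT assay, with a stated time of 72 h (a higher number here means a weaker inhibitor, a lower number a stronger inhibitor), compound 1 gives only a limit, > 128000 nM. In this assay compound 2 also gives only a limit, > 128000 nM. Compound 3 likewise gives only a limit in this assay, > 128000 nM. Compound 2 therefore stands at the limit of > 128000 nM in this assay, at which 3 of the 3 values shown sit, with no number of its own.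

Within the data shown here, the one step between compounds that differ in a single place is a step that the two limits leave unreadable from compound 2 to compound 3; it says nothing about size. Compound 1 and compound 3 differ in two places, and both of their values are limits.

Compound 4 `CC(C)(C)OC(=O)N1CCN(C(=S)SCc2cn(Cc3ccc(Cl)c(Cl)c3)nn2)CC1` is the untested member; it differs from compound 2 by tert-butyl in place of benzyl on an oxygen next to a carbonyl group. Among the measured compounds shown here, no measured step in this set covers the change from benzyloxycarbonyl to tert-butoxycarbonyl; the only guide is that compound 1, which carries tert-butoxycarbonyl, sits at the limit, and the step from compound 2 to compound 3 is unreadable. The step from compound 2 to compound 4 is therefore expected to be a step that the limit leaves unreadable from compound 2 to compound 4, with no direction readable beyond the scatter. For compound 4 in this assay the estimate is 200000 nM, between 40000 nM and 1000000 nM, most likely again reported only as a limit.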

Compound 4, half-maximal inhibitory concentration: > 128000 nM
Compound 4: no number, only a limit; the forecaster's own chance of this, stated with the estimate: 85%; the middle value does not contradict the limit.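

In this assay compound 4 gives only a limit, > 128000 nM. Among these compounds, the steps to compound 4 from compound 1 and from compound 2 cannot be read, so this result adds no new step. The compounds shown leave open whether any change on the shared core gives a number rather than a limit in this assay: the limit of > 128000 nM in this assay, at which 4 of the 4 values shown sit.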